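The compounds below may be only part of what the source reports. "The series", "measured", "known", "first", "only" and "open" are said of these compounds alone.

Within the data shown here, in a functional assay on A-431 cells (Homo sapiens) for cytotoxicity, read by MTT assay, with a stated time of 24 h (on this read-out higher numbers stand for weaker inhibition and lower numbers for stronger inhibition), compound 2 `COc1ccc(/C=C\C(=O)O)c(OCc2cn(-c3nc4ccccc4s3)nn2)c1CC=C(C)C` gives 20800 nM, the lowest of the two numbers so far, though not separated from its neighbour beyond the scatter. Compound 1 `COc1ccc(/C=C\C(=O)O)c(OCc2cn(-c3ccccc3I)nn2)c1CC=C(C)C` gives 32700 nM in this assay, and the step of a 1.6-fold lower number from compound 1 to compound 2 (0.20 log units; within the scatter) stays within the scatter. Compound 3 `COc1ccc(/C=C\C(=O)O)c(OCc2cn(-c3cccc([N+](=O)[O-])c3)nn2)c1CC=C(C)C` differs from compound 2 by 3-nitrophenyl in place of 1,3-benzothiazol-2-yl on an aromatic nitrogen. Among the measured compounds shown here, the only step that bears on this position, a 1.6-fold lower number from compound 1 to compound 2 (0.20 log units; within the scatter), was small, so compound 3 is expected to change little, with an estimated step of a 1.2-fold higher number from compound 2 to compound 3 (0.08 log units; within the scatter) that need not exceed the scatter. Compound 3 is therefore estimated at 25000 nM, between 9000 nM and 70000 nM.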

Compound 3, half-maximal inhibitory concentration: 18400 nM
Beside the measured number, compound 3's estimate is 1.4-fold (0.13 log units) above it; the measured number falls inside the stated range.
By their numbers in this assay, from the lowest: compounds 3, 2 and 1 (each within the scatter of the next).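

In this assay the new group gives a 1.1-fold lower number from compound 2 to compound 3 (0.05 log units; within the scatter) and a 1.8-fold lower number from compound 1 to compound 3 (0.25 log units; within the scatter). Both steps stay within the scatter, so 3-nitrophenyl, 1,3-benzothiazol-2-yl and 2-iodophenyl on the aromatic nitrogen cannot be told apart here. Compound 3 also shows that a group with one six-membered aromatic ring of carbon only reads like compound 2, which carries a five-membered aromatic ring with 2 hetero atoms as well. No measurement given here explains this result. The compounds shown leave open whether an amine, a carboxylic acid or a longer chain at this position would give a step beyond the scatter.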